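The source may hold more compounds than are shown below. What is called first, only, known or untested is meant among the compounds shown, and "the series" means these compounds.

Measured compounds in a functional assay on MDA-MB-231 cells (Homo sapiens) for inhibition, read by sulforhodamine B assay, tested at 10 uM; a higher number here means more inhibition at the concentration tested (going by the name of the read-out), a lower number less inhibition:
compound 1, `CN1CCN(c2ccc(C3=NNC(c4ccc(N(C)C)cc4)C3)cc2)CC1`, 11.4%
compound 2, `CN1CCN(c2ccc(C3=NN(C(=O)c4ccc(F)cc4)C(c4ccc(N(C)C)cc4)C3)cc2)CC1`, 3.5%
compound 3, `CN1CCN(c2ccc(C3=NN(S(C)(=O)=O)C(c4ccc(N(C)C)cc4)C3)cc2)CC1`, 0.6%

Compound 3 stands lowest of the three numbers in this assay . Its nearest neighbour is compound 2, and the difference a number 2.9 percentage points lower from compound 2 to compound 3 (within the scatter) is within the scatter. Its furthest is compound 1, and the difference a number 10.8 percentage points lower from compound 1 to compound 3 (beyond the scatter) is beyond the scatter, though still modest.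

Compound 4, `CN1CCN(c2ccc(C3=NN(S(=O)(=O)c4ccc(F)cc4)C(c4ccc(N(C)C)cc4)C3)cc2)CC1`, differs from compound 3 in one place: 4-fluorophenyl in place of methyl on a sulfonyl sulfur. The change is a growth of the group on the sulfonyl sulfur, from a single carbon to a six-membered aromatic ring bearing fluorine.

For the measured compounds named here, no measured step exchanges methyl for 4-fluorophenyl on a sulfonyl sulfur. The nearest parallel is compound 2, which carries a 4-fluorophenyl on a carbonyl at the same ring nitrogen and gives 3.5%, within the scatter of compound 3. The step of a number 7.9 percentage points lower from compound 1 to compound 2 (within the scatter) and the step of a number 10.8 percentage points lower from compound 1 to compound 3 (beyond the scatter) show that substituting this ring nitrogen at all lowers the number, and the step of a number 2.9 percentage points lower from compound 2 to compound 3 (within the scatter) shows that the two substituents examined so far differ by less than the scatter. The expectation is therefore no step beyond the scatter for compound 4, so that a number 2.4 percentage points higher from compound 3 to compound 4 (within the scatter) is expected to be small.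

Compound 4 is estimated at 3% in this assay , with a range from -8% to 15%.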

Compound 4, a percentage reported as inhibition, at one concentration (the size of the read-out at that concentration, not a potency): 15.7%
Beside the measured number, compound 4's estimate is 12.7 percentage points below it; measured number above the stated range.
By their numbers in this assay, from the lowest: compounds 3, 2, 1 and 4 (each within the scatter of the next, the first and the last beyond it).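

In this assay, the group on the sulfonyl sulfur turns out to matter: 4-fluorophenyl in place of methyl gives a number 15.1 percentage points higher from compound 3 to compound 4 (beyond the scatter), and keeping the 4-fluorophenyl while exchanging the carbonyl for a sulfonyl gives a number 12.2 percentage points higher from compound 2 to compound 4 (beyond the scatter), so neither the group on the sulfonyl sulfur nor the link to the ring nitrogen is interchangeable, although methylsulfonyl and (4-fluorophenyl)carbonyl had looked alike within the scatter. Substitution on this ring nitrogen therefore does not lower the number in every case, since the step to the (4-fluorophenyl)sulfonyl compound is a number 4.3 percentage points higher from compound 1 to compound 4 (within the scatter), and compound 4 thus goes against the pattern that compound 2 and compound 3 had suggested. No evidence is at hand that explains why these two changes act as they do.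

The compounds shown leave open whether the fluorine takes part in this step, which a plain phenyl on the sulfonyl sulfur would address, and whether the ring itself is needed, which a longer chain such as butyl in the same place would address. They also leave open how an amine carried on that aromatic ring would read, and whether any of these steps would hold at a concentration other than the single one tested.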